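Fluorophenyl nitrile-to-sulfone swap in a tetrahydropyrrolopyrimidine series

The source may hold more compounds than are shown below. What is called first, only, known or untested is meant among the compounds shown, and "the series" means these compounds.

Measured compounds:
compound 1, `CC(C)OC(=O)N1CCC(Oc2ncnc3c2CCN3c2ccc(S(C)(=O)=O)cc2F)CC1`: 50.1 nM
compound 2, `CC(C)OC(=O)N1CCC(Oc2ncnc3c2CCN3c2ccc(C#N)cc2F)CC1`: 63.1 nM
compound 3, `CC(C)OC(=O)N1CCC(Oc2ncnc3c2CCN3c2ccc(C#N)c(F)c2)CC1`: 398 nM

In a functional assay on CHO-K1 cells for agonist activity at Glucose-dependent insulinotropic receptor (Homo sapiens), read by a luciferase reporter, with a stated time of 5 h (on this read-out higher numbers stand for an effect only at larger amounts of compound and lower numbers for an effect already at smaller amounts), compound 1 and compound 2 give numbers within the scatter of each other, a 1.3-fold lower number from compound 2 to compound 1 (0.10 log units; within the scatter), for the change (methylsulfonyl in place of cyano on an aromatic carbon). Compound 3 differs from compound 2 in how the same atoms are joined, (4-cyano-3-fluorophenyl in place of 4-cyano-2-fluorophenyl on a nitrogen on an aromatic ring in a ring), and this carries a 6.3-fold higher number from compound 2 to compound 3 (0.80 log units; beyond the scatter); against compound 1 the gap is a 7.9-fold higher number from compound 1 to compound 3 (0.90 log units; beyond the scatter).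

Compound 4, `CC(C)OC(=O)N1CCC(Oc2ncnc3c2CCN3c2ccc(S(C)(=O)=O)c(F)c2)CC1`, is not yet measured. It differs from compound 3 by methylsulfonyl in place of cyano on an aromatic carbon. This is the same kind of change as from compound 2 to compound 1, but the place differs: there the group sits meta to a fluoro group, here ortho to a fluoro group. Within the data shown here, with only that one earlier step to rest on, compound 4 is expected to sit close to compound 3, a 1.2-fold lower number from compound 3 to compound 4 (0.09 log units; within the scatter), because a 1.3-fold lower number from compound 2 to compound 1 (0.10 log units; within the scatter) was within the scatter. The estimate for compound 4 in this assay is 320 nM, between 130 nM and 800 nM.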

Compound 4, half-maximal effective concentration: 158 nM
Compound 4: middle estimate off by 2.0-fold (0.31 log units), on the high side; measured number inside the range.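

The step of a 2.5-fold lower number from compound 3 to compound 4 (0.40 log units; beyond the scatter) in this assay is the same change that gave no step beyond the scatter on the core of compound 2, yet the two steps cannot be told apart: the same change on two cores in this assay, a 1.3-fold lower number (0.10 log units; within the scatter) from compound 2 to compound 1 and a 2.5-fold lower number (0.40 log units; beyond the scatter) from compound 3 to compound 4, 2.0-fold (0.30 log units) apart, within the scatter of two such steps. Among these compounds, this shows only that the swap of cyano for methylsulfonyl carries across these two fluorophenyl arrangements without a detectable difference; one pair of steps does not show that its size is constant on other cores. The arrangement of the aryl group still matters with methylsulfonyl in place, with a 3.2-fold higher number from compound 1 to compound 4 (0.50 log units; beyond the scatter), and the arrangement and the swap together give a 2.5-fold higher number from compound 2 to compound 4 (0.40 log units; beyond the scatter).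

As far as these compounds go, whether the same holds for other groups at this aromatic carbon, such as a primary sulfonamide or a carboxylic acid, remains open. Also open, from the compounds shown here alone, is how the swap behaves on an aryl group carrying chloro instead of fluoro.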